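Pyrimidin-4-yl replaces the bicyclic substituent on the shared core

This account rests on a few compounds, and the source may have more. Where it says the series, first, only, none or still open, it means among the compounds named here.

Compound 3 `Cn1c(=O)c(S(=O)(=O)c2ccc(F)cc2F)cc2cnc(Nc3ccc4c(c3)C(=O)C(=O)N4)nc21` gives 30000 nM in a functional assay on K562 cells (Homo sapiens) for inhibition, read by trypan blue exclusion, with a stated time of 72 h (on this read-out lower numbers stand for stronger inhibition and higher numbers for weaker inhibition), the lowest of the three numbers recorded, though its steps to both other compounds stay within the scatter. Compound 1 `Cn1c(=O)c(S(=O)(=O)c2ccc(F)cc2F)cc2cnc(Nc3ccc4[nH]ncc4c3)nc21` gives 50000 nM and compound 2 `Cn1c(=O)c(S(=O)(=O)c2ccc(F)cc2F)cc2cnc(Nc3ccccn3)nc21` gives 35000 nM. Compound 4 `Cn1c(=O)c(S(=O)(=O)c2ccc(F)cc2F)cc2cnc(Nc3ccncn3)nc21` differs from compound 3 by a group of 6 heavy atoms (4 carbon, 2 nitrogen; one six-membered aromatic ring with 2 hetero atoms) in place of a group of 11 heavy atoms (8 carbon, 1 nitrogen, 2 oxygen; one five-membered non-aromatic ring with 1 hetero atom, one six-membered aromatic ring of carbon only), on a nitrogen on an aromatic ring. The comparisons that bear on this change are a 1.2-fold lower number from compound 2 to compound 3 (0.07 log units; within the scatter) and a 1.7-fold lower number from compound 1 to compound 3 (0.22 log units; within the scatter), both within the scatter, and compound 2 already carries pyridin-2-yl on that nitrogen. Within the data shown here, since every exchange at this position so far lies inside the scatter, no step beyond it is expected in this assay. Compound 4 is therefore estimated at 35000 nM, with a range from 15000 nM to 80000 nM, which means a 1.2-fold higher number from compound 3 to compound 4 (0.07 log units; within the scatter).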

Compound 4, half-maximal inhibitory concentration: 30000 nM
For compound 4 the middle estimate is 1.2-fold (0.07 log units) above the measured one; measured number inside the range.
By their numbers in this assay, from the lowest: compounds 3, 4, 2 and 1 (each within the scatter of the next).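

In this assay, pyrimidin-4-yl, a single six-membered ring, does as well as the larger bicyclic group, with no change at the digits printed from compound 3 to compound 4 (within the scatter). Its exchanges for pyridin-2-yl, with a 1.2-fold lower number from compound 2 to compound 4 (0.07 log units; within the scatter), and for 1H-indazol-5-yl, with a 1.7-fold lower number from compound 1 to compound 4 (0.22 log units; within the scatter), also stay within the scatter, so all four groups on this nitrogen remain indistinguishable in this read-out, now including a ring with two hetero atoms. The compounds shown leave open whether any group here can move the number beyond the scatter, for instance a pyrimidin-4-yl carrying an amine or a carboxylic acid. No measurement at hand accounts for this flat picture.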